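The compounds below may be only part of what the source reports. "The series", "measured", "known", "first", "only" and "open" are said of these compounds alone.

Measured compounds:
- compound 1, `COC(=O)C1=C(N)Oc2c(OC)cc(Br)cc2C1CC(=O)c1ccc(Cl)cc1`: 80.3%
- compound 2, `COC(=O)C1=C(N)Oc2c(OC)cc(Br)cc2C1CC(=O)c1ccc(Br)cc1`: 50.2%

Going by the values given here, in a functional assay on MCF7 cells (Homo sapiens) for antiproliferative activity, read by sulforhodamine B assay, with a stated time of 72 h, tested at 10 uM (a higher number here means a weaker effect of the compound at the concentration tested, a lower number a stronger effect), compound 1 gives 80.3%, the higher of the two numbers known so far; compound 2 gives 50.2%, and the step of a number 30.1 percentage points lower from compound 1 to compound 2 (beyond the scatter) is the only measured step in the set. That step concerns bromo in place of chloro on an aromatic carbon of the aryl ketone side chain, a position that is left untouched in the change considered now.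

Compound 3, `COc1cc(Br)cc2c1OC(N)=C(C#N)C2CC(=O)c1ccc(Cl)cc1`, differs from compound 1 by cyano in place of methoxycarbonyl on a double-bonded ring carbon. Among the compounds with values here, this change sits on the fused core of compound 1, on a double-bonded ring carbon, and no measured pair varies that position. The halogen step therefore gives no guidance on size or direction; it only shows that this assay can move by a large amount on a small change. Within the data shown here, with no relevant precedent, the expectation is a step of no clear direction and no size beyond the scatter, held with wide uncertainty. Compound 3 is estimated at 75%, with a range from 45% to 95%. The expected step of a number 5.3 percentage points lower from compound 1 to compound 3 (within the scatter) is thus taken as within the scatter.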

Compound 3, a percentage reported as activity, at one concentration (the size of the read-out at that concentration, not a potency): 49.6%
Beside the measured number, compound 3's estimate is 25.4 percentage points above it; low and high end bracket the measured number.
By their numbers in this assay, from the lowest: compounds 3 and 2 (each within the scatter of the next); then compound 1.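

In this assay the double-bonded ring carbon of the shared core proves sensitive to substitution: cyano in place of methoxycarbonyl gives a number 30.7 percentage points lower from compound 1 to compound 3 (beyond the scatter) and thus a stronger effect at the concentration tested. Until now, only the halogen on the aryl ketone side chain had shown a large step, with a number 30.1 percentage points lower from compound 1 to compound 2 (beyond the scatter) as the single example, so the read-out now responds to a change at two separate places on compound 1. Nothing available bears on why the swap from methoxycarbonyl to cyano moves the number, so the step stands as an observation only.

Going by these compounds alone, the single swap changes the group as a whole, so it leaves open whether a smaller ester, a carboxylic acid or a primary carboxamide on this carbon would give a number like that of compound 3 or one like that of compound 1. Also open, as far as these compounds go, is how cyano on this carbon combines with bromo on the aryl ketone side chain, and whether the two changes would add up or overlap in this assay's read-out.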